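The source may hold more compounds than are shown below. What is called first, only, known or untested is meant among the compounds shown, and "the series" means these compounds.

Values in a functional assay on HepG2 cells (Homo sapiens) for inhibition, read by MTT assay, with a stated time of 48 h, tested at 10 uM (on this read-out lower numbers stand for less inhibition of growth and higher numbers for more inhibition of growth at the one concentration tested), for the measured compounds:
compound 1 `O=C(/C=C/c1ccc(OCc2cn(Cc3ccccc3Br)nn2)cc1)c1ccc(Br)cc1` gives 34%
compound 2 `O=C(/C=C/c1ccc(OCc2cn(Cc3cccc(Br)c3)nn2)cc1)c1ccc(Br)cc1` gives 25%
compound 3 `COc1ccc(C(=O)/C=C/c2ccc(OCc3cn(Cc4ccccc4Br)nn3)cc2)cc1` gives 44%

Compound 1 and compound 2 differ in one place, (3-bromophenyl in place of 2-bromophenyl on a saturated chain carbon bound to an aromatic nitrogen); the step of a number 9 percentage points lower from compound 1 to compound 2 (within the scatter) is within the scatter. Compound 3 differs from compound 1 in the core, (methoxy in place of bromo on an aromatic carbon), and the step of a number 10 percentage points higher from compound 1 to compound 3 (within the scatter) is also within the scatter. Compound 3 holds the highest number of the three, but only its gap to compound 2 lies beyond the scatter; its gap to compound 1 does not.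

Compound 4 `COc1ccc(C(=O)/C=C/c2ccc(OCc3cn(Cc4cccc(Br)c4)nn3)cc2)cc1` is not yet measured. It differs from compound 3 in 3-bromophenyl in place of 2-bromophenyl on a saturated chain carbon bound to an aromatic nitrogen, which is the same change as that between compound 1 and compound 2, at the same place, carried over to the core of compound 3. In this assay, among the compounds with values here, the expected step is a number 9 percentage points lower from compound 3 to compound 4 (within the scatter), because a number 9 percentage points lower from compound 1 to compound 2 (within the scatter) is the one measured instance of this change and a step of similar size and direction is expected here. In this assay compound 4 is estimated at 35%, within a range from 22% to 48%.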

Compound 4, percent growth inhibition at one concentration: 27%
For compound 4 the middle estimate is 8 percentage points above the measured one; low and high end bracket the measured number.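

In this assay, 3-bromophenyl in place of 2-bromophenyl gives a number 17 percentage points lower from compound 3 to compound 4 (beyond the scatter), and the two instances of this change point the same way without differing beyond the scatter of two such steps: the same change on two cores in this assay, a number 9 percentage points lower (within the scatter) from compound 1 to compound 2 and a number 17 percentage points lower (beyond the scatter) from compound 3 to compound 4, 8 percentage points apart, within the scatter of two such steps

Methoxy in place of bromo on an aromatic carbon gives a number 2 percentage points higher from compound 2 to compound 4 (within the scatter), and this change also carries over between the two cores without a difference beyond that scatter: the same change on two cores in this assay, a number 10 percentage points higher (within the scatter) from compound 1 to compound 3 and a number 2 percentage points higher (within the scatter) from compound 2 to compound 4, 8 percentage points apart, within the scatter of two such steps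

Within the data shown here, this supports a direction for the bromophenyl change on these two cores only, but it does not fix the size of the step, since only one of the two steps lies beyond the scatter, and it says nothing about any third core.

As far as these compounds go, whether an amine or a carboxylic acid on the aromatic carbon now holding bromo or methoxy, or a longer chain in place of the saturated chain carbon bound to the aromatic nitrogen, would follow the same steps remains open. From the compounds shown here alone, how these readings at one concentration relate to behaviour at other concentrations also remains open.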